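The compounds below may be only part of what the source reports. "The series", "measured", "known", "first", "only" and "open" are said of these compounds alone.

Measured in an ADME assay on the whole organism (Rattus norvegicus, strain Sprague-Dawley) for protein binding, read by LC-MS, with a stated time of 30 min, at a dose of 1 mg/kg by the intravenous route; a higher number here means faster removal of the compound, a lower number slower removal:
- compound 1 `N#Cc1ccc(S(=O)(=O)[C@H]2CN(S(=O)(=O)c3ccc(Cl)cc3Cl)C[C@@]2(O)CO)cc1`: 9 mL/min/kg
- compound 2 `N#Cc1ccc(S(=O)(=O)[C@H]2CN(S(=O)(=O)c3ccc(Cl)cc3Cl)C[C@@]2(O)CO)cc1F`: 14 mL/min/kg
- compound 3 `N#Cc1ccc(S(=O)(=O)[C@H]2CN(S(=O)(=O)c3ccc(Cl)cc3C#N)C[C@@]2(O)CO)cc1`: 7 mL/min/kg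

Compound 3, at 7 mL/min/kg, lies within the scatter of both compound 1 and compound 2. Compound 4 `N#Cc1ccc(S(=O)(=O)[C@H]2CN(S(=O)(=O)c3ccc(C#N)cc3Cl)C[C@@]2(O)CO)cc1` differs from compound 3 by 2-chloro-4-cyanophenyl in place of 4-chloro-2-cyanophenyl on a sulfonyl sulfur. Among the measured compounds shown here, no measured pair shows this exchange directly. For the measured compounds named here, two steps bear on it only indirectly: cyano in place of chloro gave a 1.3-fold lower number from compound 1 to compound 3 (0.11 log units; within the scatter), and fluoro in place of hydrogen gave a 1.6-fold higher number from compound 1 to compound 2 (0.19 log units; within the scatter). Both stay within the scatter, so no step beyond it is expected. The expected change is a 1.1-fold higher number from compound 3 to compound 4 (0.06 log units; within the scatter). Compound 4 is estimated at 8 mL/min/kg, with an expected range of 4 mL/min/kg to 15 mL/min/kg.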

Compound 4, clearance in the Rattus norvegicus assay: 4 mL/min/kg
Estimate against measurement, compound 4: 2.0-fold (0.30 log units) above; low and high end bracket the measured number.
By their numbers in the Rattus norvegicus assay, from the lowest: compounds 4, 3, 1 and 2 (each within the scatter of the next, the first and the last beyond it).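

In the Rattus norvegicus assay, compound 3 gives 7 mL/min/kg and compound 4 gives 4 mL/min/kg. In the Rattus norvegicus assay, 2-chloro-4-cyanophenyl in place of 4-chloro-2-cyanophenyl on a sulfonyl sulfur gives a 1.8-fold lower number from compound 3 to compound 4 (0.24 log units; within the scatter), so this rearrangement of the same atoms has no effect that can be told from the scatter. In the Rattus norvegicus assay, cyano in place of chloro gives a 2.3-fold lower number from compound 1 to compound 4 (0.35 log units; beyond the scatter), a modest step beyond the scatter, whereas the same kind of exchange gave a 1.3-fold lower number from compound 1 to compound 3 (0.11 log units; within the scatter). In a physicochemical assay for solubility, read by chemiluminescence, measured as kinetic solubility (on this read-out higher numbers stand for higher solubility and lower numbers for lower solubility), compound 3 gives 380000 nM and compound 4 gives 400000 nM. In the physicochemical assay, the rearrangement gives a 1.1-fold higher number from compound 3 to compound 4 (0.02 log units; within the scatter).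

Nothing measured here accounts for these numbers. As far as these compounds go, whether an amine or a carboxylic acid in place of the nitrile would hold the clearance at this level stays open.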